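Chloro to Fluoro on the Aryl Ring: Predicting Compound 4

The compounds below may be only part of what the source reports. "The series", "measured", "known", "first", "only" and "open" are said of these compounds alone.

Measured compounds:
compound 1 `C/C(=N\NC(=S)Nc1ccccc1Cl)c1ccccn1`, 0.16 nM
compound 2 `C/C(=N\NC(=S)Nc1ccccc1F)c1ccccn1`, 0.39 nM
compound 3 `CC(=NNC(=S)Nc1ccc(Cl)cc1)c1ccccn1`, 8.5 nM

In a functional assay on MCF7 cells (Homo sapiens) for cytotoxicity, read by MTT assay, with a stated time of 48 h (a higher number here means a weaker inhibitor, a lower number a stronger inhibitor), compound 1 gives 0.16 nM, while compound 2 gives 0.39 nM. The change between them, (fluoro in place of chloro on an aromatic carbon), produced a 2.4-fold higher number from compound 1 to compound 2 (0.39 log units; beyond the scatter). Compound 3 gives 8.5 nM, the highest of the three; how its core differs from that of compound 1 is not broken down here. Compound 4 `CC(=NNC(=S)Nc1ccc(F)cc1)c1ccccn1` is not yet measured. It differs from compound 3 by fluoro in place of chloro on an aromatic carbon, the same kind of change as that from compound 1 to compound 2, though the place differs: ortho to a large group in the first pair, para to a large group in this one. Because compound 1 to compound 2 gave a 2.4-fold higher number from compound 1 to compound 2 (0.39 log units; beyond the scatter), a similar step is expected here, a 2.4-fold higher number from compound 3 to compound 4 (0.37 log units; beyond the scatter), so compound 4 is estimated at 20 nM, within 6 nM to 60 nM.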

Compound 4, half-maximal inhibitory concentration: 1.2 nM
Compound 4: middle estimate off by 17-fold (1.22 log units), on the high side; the whole stated range lies above it.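

In this assay fluoro in place of chloro gave a 7.1-fold lower number from compound 3 to compound 4 (0.85 log units; beyond the scatter) and so ran in the opposite direction to the earlier pair, a clear gap between the two cores: the same change on two cores in this assay, a 2.4-fold higher number (0.39 log units; beyond the scatter) from compound 1 to compound 2 and a 7.1-fold lower number (0.85 log units; beyond the scatter) from compound 3 to compound 4, 17-fold (1.24 log units) apart, beyond the scatter of two such steps

This change therefore cannot be carried from one core to another in this series as a fixed step. The result does not show why, since the swap sits para to a large group only in the second pair, and two pairs cannot reveal a general rule.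

The compounds shown leave open how bromo, methyl, methoxy or an amine would behave at the same place on the ring. They also leave open whether the ring with no halogen at all would give a number closer to the fluoro or the chloro compounds.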